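The source may hold more compounds than are shown below. What is called first, only, known or untested is meant among the compounds shown, and "the series" means these compounds.

Compound 1 `CC1CCN(Cc2ccc3nc(NC(=O)N/N=C/c4cn(Cc5cccc(Cl)c5)c5ccccc45)sc3c2)CC1` belongs to a small set of three compounds built on the same core and tested in a functional assay on MDA-MB-231 cells (Homo sapiens) for cytotoxicity, read by MTT assay, with a stated time of 72 h (a higher number here means a weaker inhibitor, a lower number a stronger inhibitor), where compound 1 gives 2110 nM. Its two companions differ from it only in the group sitting on a saturated chain carbon bound to an aromatic nitrogen. Compound 2 `CC1CCN(Cc2ccc3nc(NC(=O)N/N=C/c4cn(Cc5ccccc5Cl)c5ccccc45)sc3c2)CC1` gives 1360 nM and compound 3 `CC1CCN(Cc2ccc3nc(NC(=O)N/N=C/c4cn(Cc5ccc(C(C)(C)C)cc5)c5ccccc45)sc3c2)CC1` gives 3880 nM. The number for compound 1 lies within the scatter of both companions: the steps of a 1.6-fold lower number from compound 1 to compound 2 (0.19 log units; within the scatter) and a 1.8-fold higher number from compound 1 to compound 3 (0.26 log units; within the scatter) are small, while a 2.9-fold higher number from compound 2 to compound 3 (0.46 log units; beyond the scatter) is modest. Compound 4 `CCN(CC)Cc1ccc2nc(NC(=O)N/N=C/c3cn(Cc4cccc(Cl)c4)c4ccccc34)sc2c1` alters a different part of the molecule: diethylamino in place of 4-methylpiperidin-1-yl on a saturated chain carbon bound to an aromatic carbon. For the measured compounds named here, none of the three measured steps touches this position, so they give no direct guidance; they show only that changes at the other position moved the number by a modest step at most. The expected step is therefore a 1.1-fold higher number from compound 1 to compound 4 (0.06 log units; within the scatter), nothing beyond the scatter. Compound 4 is estimated at 2400 nM, with a range from 1000 nM to 6000 nM.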

Compound 4, half-maximal inhibitory concentration: 2050 nM
Estimate against measurement, compound 4: 1.2-fold (0.07 log units) above; measured number inside the range.
By their numbers in this assay, from the lowest: compounds 2, 4, 1 and 3 (each within the scatter of the next, the first and the last beyond it).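

For the compounds shown here, at the position on a saturated chain carbon bound to an aromatic carbon, diethylamino in place of 4-methylpiperidin-1-yl gives a 1.0-fold lower number from compound 1 to compound 4 (0.01 log units; within the scatter) in this assay, which is the first direct reading at this site. The change opens the ring and goes from 7 heavy atoms to 5, yet the step stays within the scatter, so in this one pair the ring of the amine is not needed to keep the number where it stands. Nothing shown here explains why the two amines read alike.

A single pair cannot show how much change this position accepts, so a morpholin-4-yl group, a primary amine or a carboxylic acid at the same place remains an open case. From the compounds shown here alone, it is also open whether diethylamino would read the same alongside the 2-chlorophenyl group of compound 2.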